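This account rests on a few compounds, and the source may have more. Where it says the series, first, only, none or still open, it means among the compounds named here.

In a functional assay on HL-60 cells (Homo sapiens) for cytotoxicity, read by WST assay, with a stated time of 48 h (on this read-out lower numbers stand for an effect already at smaller amounts and higher numbers for an effect only at larger amounts of compound), compound 1 `O=C1OC[C@H](Cc2ccccc2)[C@H]1Cc1ccc(Cl)cc1` gives 36000 nM and compound 2 `O=C1OC[C@H](Cc2ccccc2)[C@H]1Cc1ccc(Cl)c(Cl)c1` gives 19000 nM as its value. For the measured compounds named here, these two values lie within the scatter of each other, so compound 2 stands level with the only other measured compound and neither can be ranked. Compound 3 `O=C1OC[C@H](Cc2ccccc2O)[C@H]1Cc1ccc(Cl)c(Cl)c1` keeps the core of compound 2 and takes hydroxy in place of hydrogen on an aromatic carbon, ortho to a large group, the change from phenyl to 2-hydroxyphenyl, with hydroxy in place of hydrogen on an aromatic carbon as the counted difference. Going by the values given here, the only measured step is a 1.9-fold lower number from compound 1 to compound 2 (0.28 log units; within the scatter) for a chloro replacement, not a hydroxy one. That step stays within the scatter, yet it says nothing direct about hydroxy. Nothing measured here tests that group, so no step beyond the scatter is expected in this assay and only a faint lean towards a lower number is assumed. The expected step is a 1.4-fold lower number from compound 2 to compound 3 (0.13 log units; within the scatter) on this estimate. Compound 3 is estimated at 14000 nM with an expected range from 5000 nM to 40000 nM on this read-out.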

Compound 3, half-maximal effective concentration: 33000 nM
Compound 3: the middle estimate sits 2.4-fold (0.37 log units) below what was measured; the range from low to high includes it.
By their numbers in this assay, from the lowest: compounds 2, 3 and 1 (each within the scatter of the next).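

In this assay, the change from phenyl to 2-hydroxyphenyl gives a 1.7-fold higher number from compound 2 to compound 3 (0.24 log units; within the scatter), so this first change on the phenyl leaves compound 3 level with compound 2, and no effect of hydroxy at this place can be read. The step between compound 1 and compound 2 concerned only chloro on the other aromatic ring, whereas this result shows that a group with a hydrogen-bond donor and acceptor can enter on an aromatic carbon, ortho to a large group, without a step beyond the scatter. No measurement shown offers an explanation for this outcome.

The compounds shown leave open whether a different group at this place, such as methoxy, an amine or a carboxylic acid, would produce a step beyond the scatter. They also leave open whether hydroxy would give the same result elsewhere on the phenyl, or on the core of compound 1, which carries one chloro fewer than compound 2.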